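Methyl in place of hydrogen on compound 3

This account rests on a few compounds, and the source may have more. Where it says the series, first, only, none or still open, it means among the compounds named here.

Compound 3 `CN1C(=O)COc2cc(Nc3ncc4ncn(CC5CC5)c4n3)cnc21` stands second highest of three in an ADME assay on microsomes from liver (Rattus norvegicus) for metabolic stability (on this read-out higher numbers stand for a longer-lived compound and lower numbers for a shorter-lived compound), at 0.3 h, above compound 1 `CN1C(=O)COc2cc(Nc3ccc4ncn(CC5CC5)c4n3)cnc21` at 0.117 h, while compound 2 `CN1C(=O)COc2cc(Nc3cc(C(F)(F)F)c4ncn(CC5CC5)c4n3)cnc21` gives the highest number at 1.12 h, with both gaps beyond the scatter. Compound 4 `Cc1nc(Nc2cnc3c(c2)OCC(=O)N3C)nc2c1ncn2CC1CC1` carries one change, methyl in place of hydrogen on an aromatic carbon. Going by the values given here, the only measured step of this kind is a 9.6-fold higher number from compound 1 to compound 2 (0.98 log units; beyond the scatter), with trifluoromethyl in place of hydrogen on an aromatic carbon, and it lies beyond the scatter. Among the compounds with values here, no measured step has methyl as the entering group, so that step is a loose guide. In this assay a smaller rise in the same direction is expected, possibly not clearing the scatter. The expected step is a 1.7-fold higher number from compound 3 to compound 4 (0.22 log units; within the scatter). The estimate for compound 4 is 0.5 h, with an expected range of 0.2 h to 1.2 h.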

Compound 4, half-life: 0.917 h
Compound 4: the middle estimate sits 1.8-fold (0.26 log units) below what was measured, and the stated range covers the measured number.
By their numbers in this assay, from the lowest: compound 1; then compound 3; then compounds 4 and 2 (each within the scatter of the next).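

In this assay, methyl in place of hydrogen gives a 3.1-fold higher number from compound 3 to compound 4 (0.49 log units; beyond the scatter), so a single carbon on this aromatic carbon, next to the ring nitrogen, is enough to clear the scatter. The earlier trifluoromethyl step, a 9.6-fold higher number from compound 1 to compound 2 (0.98 log units; beyond the scatter), came from a different core, and these two steps are the only substitutions shown, both rising. Nothing measured here accounts for the rise. Open, on these data alone, is how an ethyl, a methoxy or an amine at this carbon would read, and whether methyl gives a similar rise on the core of compound 1.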